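The source may report more compounds than this note shows. Statements on the series, on what has been measured and on what is new or still open speak of the compounds shown alone.

Compound 1 `O=S(=O)(Nc1ccc(-c2nc3ccccc3o2)cc1)c1ccccc1F` — in an assay on cells for inhibition of HSP60/HSP10 (Homo sapiens), with a stated time of 60 min (on this read-out higher numbers stand for weaker inhibition and lower numbers for stronger inhibition), compound 1 gives > 100000 nM, a limit of the assay.
Compound 2 `O=S(=O)(Nc1ccc(-c2nc3ccccc3o2)cc1)c1ccccc1O` — in this assay compound 2 gives > 100000 nM, a limit of the assay.
Compound 3 `COc1ccc(Cl)cc1S(=O)(=O)Nc1ccc(-c2nc3ccccc3o2)cc1` — in this assay compound 3 gives > 100000 nM, a limit of the assay.

Compound 3 therefore stands only at a limit, and all three measured values sit at the limit of > 100000 nM in this assay, at which 3 of the 3 values shown sit. The next compound, compound 4 `Cc1cccc(S(=O)(=O)Nc2ccc(-c3nc4ccccc4o3)cc2)c1`, differs from compound 3 in one place: 3-methylphenyl in place of 5-chloro-2-methoxyphenyl on a sulfonyl sulfur. Among the compounds with values here, the steps that bear on this change are a step that the two limits leave unreadable from compound 1 to compound 3 and a step that the two limits leave unreadable from compound 2 to compound 3. Both are unreadable, since every value involved is a limit. Nothing here shows that any aryl group on the sulfonyl sulfur produces measurable inhibition, so compound 4 is expected to remain at the limit as well, with the step that the limit leaves unreadable from compound 3 to compound 4 carrying little meaning. The estimate for compound 4 in this assay is 150000 nM, within 30000 nM to 1000000 nM.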

Compound 4, half-maximal inhibitory concentration: > 100000 nM
Compound 4 gave a limit, no number (the forecaster's own chance of this, stated with the estimate: 85%); the middle value lies beyond the limit too.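

The steps to compound 4 from compound 1, compound 2 and compound 3 cannot be read, since all four compounds stand at the same limit: the limit of > 100000 nM in this assay, at which 4 of the 4 values shown sit. The compounds shown leave open whether any aryl group on the sulfonyl sulfur gives measurable inhibition.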